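Sulfonamide series: compound 2 to compound 3

The source may hold more compounds than are shown below. What is called first, only, known or untested is meant among the compounds shown, and "the series" means these compounds.

Among the compounds with values here, in an ADME assay (liver) for metabolic stability, with Liver microsome (Homo sapiens) as the target, read by LC-MS, using microsomes and NADPH, with a stated time of 5 min, at 37 degrees C (on this read-out higher numbers stand for fast clearance and lower numbers for slow clearance), compound 2 `CCn1cc(S(=O)(=O)N[C@H](C)c2nc3ccc(C(F)(F)F)cc3n2CC)cn1` gives 95 mL.min-1.g-1 as the only true number so far. Compound 1 `CCn1c([C@@H](C)NS(=O)(=O)C2CC2)nc2ccc(C(F)(F)F)cc21` gives < 3 mL.min-1.g-1 and this is a limit of the assay, not a number. Within the data shown here, the single measured step of an at least 31-fold higher number from compound 1 to compound 2 (1.50 log units; beyond the scatter) is large and beyond the scatter. It rests on that limit (the limit of < 3 mL.min-1.g-1 in this assay, at which 1 of the 2 values shown sits) and brings 1-ethyl-1H-pyrazol-4-yl in place of cyclopropyl on a sulfonyl sulfur. Compound 3 `CCn1c([C@@H](C)NS(=O)(=O)c2cnn(C(C)C)c2C)nc2ccc(C(F)(F)F)cc21` changes compound 2 on that same sulfonyl sulfur (1-isopropyl-5-methyl-1H-pyrazol-4-yl in place of 1-ethyl-1H-pyrazol-4-yl on a sulfonyl sulfur). Both groups hold one five-membered aromatic ring with 2 hetero atoms, so the exchange behind that large step does not recur, and the expectation in this assay stays near compound 2 (95 mL.min-1.g-1). The expected size of the step is a 1.2-fold higher number from compound 2 to compound 3 (0.06 log units; within the scatter) and no change beyond the scatter is expected. Compound 3 is estimated at 110 mL.min-1.g-1 with a range of 45 mL.min-1.g-1 to 250 mL.min-1.g-1 expected.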

Compound 3, intrinsic clearance in microsomes: > 100 mL.min-1.g-1
Compound 3: no number, only a limit (the forecaster's own chance of this, stated with the estimate: 3%); the middle value does not contradict the limit.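

Compound 3 gives > 100 mL.min-1.g-1 in this assay, and this is a limit of the assay, not a number. Measured against cyclopropyl on the sulfonyl sulfur, the result is an at least 33-fold higher number from compound 1 to compound 3 (1.52 log units; beyond the scatter), so the large difference now holds for two groups with one five-membered aromatic ring with 2 hetero atoms, not for 1-ethyl-1H-pyrazol-4-yl alone. Between the two such groups, only a floor can be read, an at least 1.0-fold higher number from compound 2 to compound 3 (0.02 log units; that floor lies within the scatter), so the isopropyl and methyl groups bring no return towards the cyclopropyl value, while any further rise stays unread.

Open, as far as these compounds go, is how far beyond its limit compound 3 really lies. Also open, from the compounds shown here alone, is whether the difference from cyclopropyl follows the pyrazole ring or its alkyl groups, which a pyrazol-4-yl without alkyl groups, a phenyl ring or a dimethylamino group on the sulfonyl sulfur would address.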